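Piperidine sulfone series: liver microsome stability notes

This account rests on a few compounds, and the source may have more. Where it says the series, first, only, none or still open, it means among the compounds named here.

Measured compounds:
- compound 1 `O=C(O)[C@H]1CC[C@](F)(C(=O)N2CC[C@](c3ccc(C(F)(C(F)(F)F)C(F)(F)F)cc3)(S(=O)(=O)c3ccc(F)cc3)C2)CC1`, an ADME assay on microsomes from liver (Mus musculus) for metabolic stability, with a stated time of 10 min; a lower number here means that less of the compound is left, a higher number that more of the compound is left: "not determined" (no result reported)
- compound 2 `CS(=O)(=O)C1CCC(C(=O)N2CC[C@](c3ccc(C(F)(C(F)(F)F)C(F)(F)F)cc3)(S(=O)(=O)c3ccc(F)cc3)C2)CC1`, this assay: 69%; "not determined" (no result reported) (2 entries)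

Compound 1 stands without a number in this assay; its further entry also carries none, so its place on the scale is open. Compound 3 `O=C(N1CC[C@](c2ccc(C(F)(C(F)(F)F)C(F)(F)F)cc2)(S(=O)(=O)c2ccc(F)cc2)C1)C1(CO)CCS(=O)(=O)CC1` carries 4-(hydroxymethyl)-1,1-dioxothian-4-yl in place of 4-carboxy-1-fluorocyclohexyl on a carbonyl carbon. Among the measured compounds shown here, with no measured step for this change, the only anchor is compound 2, whose entries read (the several entries of compound 2 in this assay, 69%; "not determined" (no result reported) (2 entries)). Against that anchor the step from compound 1 to compound 3 is taken as no change beyond the scatter. Compound 3 is expected to show about 65%, estimated between 40% and 90%.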

Compound 3, percent of the compound remaining: 31%
Estimate against measurement, compound 3: 34 percentage points above; measured number outside the range, below it.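

Among the compounds shown here, no step from compound 1 to compound 3 can be read in this assay: compound 1 carries no number there. The compounds shown leave open how replacing 4-carboxy-1-fluorocyclohexyl with 4-(hydroxymethyl)-1,1-dioxothian-4-yl shifts the percent of compound remaining.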